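This account rests on a few compounds, and the source may have more. Where it says the series, first, only, none or still open, it means among the compounds named here.

Among the compounds with values here, compound 2 `O=C(O)CC[C@H](NC(=O)[C@]1(O)C[C@@H](O)[C@@H](O)[C@H](O)C1)C(=O)O` holds the highest of the two numbers so far: in an assay on HL-60 cells for inhibition of P-selectin (Homo sapiens), tested at 50 mM (a higher number here means more inhibition at the concentration tested (going by the name of the read-out), a lower number less inhibition), compound 2 gives 86%, while compound 1 `O=C(O)CNC(=O)[C@]1(O)C[C@@H](O)[C@@H](O)[C@H](O)C1` gives 38%. Within the data shown here, the one measured step, a number 48 percentage points higher from compound 1 to compound 2 (beyond the scatter), bears directly on what follows. Compound 3 `C[C@H](NC(=O)[C@]1(O)C[C@@H](O)[C@@H](O)[C@H](O)C1)C(=O)O` differs from compound 2 by hydrogen in place of carboxymethyl on a saturated chain carbon, two bonds along the chain from an amide-type nitrogen and a carbonyl carbon, so compound 3 keeps only part of what compound 2 adds to compound 1. Because a number 48 percentage points higher from compound 1 to compound 2 (beyond the scatter) was large, a downward step is expected, a number 34 percentage points lower from compound 2 to compound 3 (beyond the scatter), though a partial one. Compound 3 is estimated at 52%, with a range from 30% to 75%.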

Compound 3, a percentage reported as inhibition, at one concentration (the size of the read-out at that concentration, not a potency): 8%
Beside the measured number, compound 3's estimate is 44 percentage points above it; the whole stated range lies above it.
By their numbers in this assay, from the lowest: compound 3; then compound 1; then compound 2.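

At the saturated chain carbon bound to an amide-type nitrogen and a carbonyl carbon, this assay does not reward just any carbon group: methyl in place of hydrogen gives a number 30 percentage points lower from compound 1 to compound 3 (beyond the scatter) and not a gain. Cutting 2-carboxyethyl back to methyl gives a number 78 percentage points lower from compound 2 to compound 3 (beyond the scatter) here, so the carboxymethyl part of that chain is needed for the high number of compound 2. Nothing measured here gives a reason for these changes. Still open, on these data alone, is whether the end carboxylic acid itself matters, or whether a chain of the same length ending in an amine would do as well.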